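The compounds below may be only part of what the source reports. "The series", "measured", "known", "first", "only" and "open" are said of these compounds alone.

Compound 3, whose structure is `CCC(C)N(C(=O)[C@H](CC(=O)OC)NC(=O)OC(C)(C)C)C1(C(=O)NCc2ccccc2)CCN(Cc2ccccc2)CC1`, gives 84000 nM in an ADME assay on MDCK cells (Canis lupus familiaris) for cytotoxicity, read by microscopy, with a stated time of 72 h (a lower number here means that less compound is tolerated, a higher number that more compound is tolerated), the highest of the three numbers recorded. Compound 2, with structure `COC(=O)C[C@H](NC(=O)OC(C)(C)C)C(=O)N(Cc1ccc(F)cc1)C1(C(=O)NC(C)(C)C)CCN(Cc2ccccc2)CC1`, gives 80000 nM in this assay, and the two values lie within the usual scatter of each other, so nothing separates them. Compound 1, whose structure is `COC(=O)C[C@H](NC(=O)OC(C)(C)C)C(=O)N(Cc1ccc(F)cc1)C1(C(=O)NCc2ccccc2)CCN(c2ccccc2)CC1`, gives 20000 nM in this assay, a lower number than compound 3 by a margin that goes beyond the scatter; compound 1 also carries a phenyl on the saturated ring nitrogen where compounds 2 and 3 carry a benzyl.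

Compound 4, with structure `COC(=O)C[C@H](NC(=O)OC(C)(C)C)C(=O)N(Cc1ccc(F)c(F)c1)C1(C(=O)NCc2ccccc2)CCN(Cc2ccccc2)CC1`, has not been measured. It differs from compound 3 in one place: 3,4-difluorobenzyl in place of sec-butyl on an amide-type nitrogen. Compound 2, which already carries a fluorine-bearing benzyl on its amide-type nitrogen, gives 80000 nM in this assay, so a small downward step, if any, is expected from compound 3 to compound 4, of about a 1.4-fold lower number from compound 3 to compound 4 (0.15 log units; within the scatter). On this basis compound 4 is estimated at 60000 nM in this assay, within a range from 25000 nM to 100000 nM.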

Compound 4, minimum cytotoxic concentration: 20000 nM
Beside the measured number, compound 4's estimate is 3.0-fold (0.48 log units) above it; the whole stated range lies above it.
By their numbers in this assay, from the lowest: compounds 1 and 4 (each within the scatter of the next); then compounds 2 and 3 (each within the scatter of the next).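

In this assay, the step from sec-butyl to 3,4-difluorobenzyl on the amide-type nitrogen gives a 4.2-fold lower number from compound 3 to compound 4 (0.62 log units; beyond the scatter). This is the first change confined to one place among these compounds, and it shows that the group at this position can move the number beyond the scatter, even though the hydrogen-bond donor and acceptor counts and the net charge stay the same on both sides. Nothing shown bears on the reason for this step.

On these data alone, the change brings in an aromatic ring and two fluorines together, so it remains open which of them goes with the lower number; an unsubstituted benzyl or a cyclohexylmethyl group at this nitrogen would separate the two. As far as these compounds go, it is also open whether the step would hold with the other groups of the shared core changed.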